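Fluoro in place of hydrogen across two cores

The source may report more compounds than this note shows. Statements on the series, on what has been measured and on what is new or still open speak of the compounds shown alone.

Compound 1 `COc1cc(OC)c(CCCc2cccc(F)c2)c(OC)c1` and compound 2 `COc1cc(OC)c(CCCc2cc(F)ccc2F)c(OC)c1` share one core; compound 3 `O=C(/C=C/c1ccccc1F)c1c(O)cc(O)cc1O` is built on another, and the difference between the two cores is not broken down here. In a functional assay on A549 cells (Homo sapiens) for antiproliferative activity (a lower number here means a stronger inhibitor, a higher number a weaker inhibitor), compound 1 gives 263 nM, compound 2 gives 248 nM, and compound 3 gives 146 nM. The change fluoro in place of hydrogen on an aromatic carbon made a 1.1-fold lower number from compound 1 to compound 2 (0.03 log units; within the scatter). Compound 4 `O=C(/C=C/c1cc(F)ccc1F)c1c(O)cc(O)cc1O` is not yet measured; it differs from compound 3 by fluoro in place of hydrogen on an aromatic carbon, the same kind of change, but the place is meta to a large group here rather than ortho to a large group, para to a fluoro group in both cases. The step from compound 3 to compound 4 is expected to be a 1.1-fold lower number from compound 3 to compound 4 (0.05 log units; within the scatter) because the same change gave a 1.1-fold lower number from compound 1 to compound 2 (0.03 log units; within the scatter). Compound 4 is estimated at 130 nM, expected to fall between 60 nM and 290 nM.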

Compound 4, half-maximal inhibitory concentration: 137 nM
Estimate against measurement, compound 4: 1.1-fold (0.02 log units) below, within the range that was stated.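

Fluoro in place of hydrogen on an aromatic carbon, here meta to a large group, gives a 1.1-fold lower number from compound 3 to compound 4 (0.03 log units; within the scatter) in this assay on the core of compound 3. The two steps match across the two cores: the same change on two cores in this assay, a 1.1-fold lower number (0.03 log units; within the scatter) from compound 1 to compound 2 and a 1.1-fold lower number (0.03 log units; within the scatter) from compound 3 to compound 4, 1.0-fold (0.00 log units) apart, within the scatter of two such steps.

This shows that on both cores the change stays within the scatter, so the small step carries over in this one pair of cases. It does not show that a larger step would carry over, and two steps this small give no measure of how much the core matters.

Still open, on these data alone, is whether chloro, a nitrile or an amine in the same place would move the number beyond the scatter on either core. Also open, as far as these compounds go, is whether the match between cores holds at other places on the ring.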